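The source may hold more compounds than are shown below. What is called first, only, known or untested is meant among the compounds shown, and "the series" means these compounds.

Values in a functional assay on PC-3 cells (Homo sapiens) for cytotoxicity, read by MTT assay, with a stated time of 72 h; on this read-out higher numbers stand for weaker inhibition and lower numbers for stronger inhibition:
- compound 1 `CNC(=O)c1cc(Oc2ccc(C3=NNC(c4cccc([N+](=O)[O-])c4)C3)cc2)ccn1`: "not determined" (no result reported)
- compound 2 `CNC(=O)c1cc(Oc2ccc(C3=NNC(c4ccc(F)cc4)C3)cc2)ccn1`: 6770 nM
- compound 3 `CNC(=O)c1cc(Oc2ccc(C3=NNC(c4cccc(Cl)c4Cl)C3)cc2)ccn1`: "not determined" (no result reported)

Compound 1 has no single number on this read-out, and compound 3 also lacks one, so compound 2 at 6770 nM is the sole numerical anchor. Compound 4 `CNC(=O)c1cc(Oc2ccc(C3=NN(C(N)=S)C(c4cccc([N+](=O)[O-])c4)C3)cc2)ccn1` keeps the core of compound 1 and carries one change: a group of 3 heavy atoms (1 carbon, 1 nitrogen, 1 sulfur; no ring) in place of a hydrogen atom, on an amine nitrogen in a ring. The new group replaces a hydrogen atom on an amine nitrogen in a ring. Going by the values given here, no measured step in this assay shows the effect of this change. A moderate move toward stronger inhibition is expected, relative to compound 2 at 6770 nM, though the data offer no direct support. For compound 4 the estimated value is 3000 nM, with an expected range from 800 nM to 12000 nM.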

Compound 4, half-maximal inhibitory concentration: > 50000 nM
Compound 4 was reported as a limit; the forecaster's own chance of this, stated with the estimate: 10%; middle value at least 16-fold (1.22 log units) away from the limit.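

In this assay compound 4 gives > 50000 nM, which is a limit and not a number. Going by these compounds alone, compound 1 has no single number, so no step between compound 1 and compound 4 can be read. The compounds shown leave open how the new group on the ring nitrogen shifts inhibition.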